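The compounds below may be only part of what the source reports. "The series", "measured", "known", "first", "only" and "open" are said of these compounds alone.

Working notes on the series. For the measured compounds named here, in an ADME assay on BJ cells (Homo sapiens) for cytotoxicity, with a stated time of 72 h (a higher number here means that more compound is needed for the effect, a lower number that less compound is needed), compound 1 `COC(=O)c1cccc(NC(=O)Nc2cc(C)nc3ccccc23)c1` gives 21000 nM, the only actual number available so far. Compound 2 `Cc1cc(NC(=O)Nc2ccc(C(=O)O)cc2)c2ccccc2n1` reads > 25000 nM, which is a limit of the assay and not a number. No order between these two compounds can be read from this.

The next compound is compound 3 `Cc1cc(NC(=O)Nc2cccc(C(C)(C)C)c2)c2ccccc2n1`, and the change from the first compound is tert-butyl in place of methoxycarbonyl on an aromatic carbon. In words, tert-butyl stands in place of methoxycarbonyl on an aromatic carbon, meta to a large group. Going by the values given here, no measured step covers this change, so the expectation rests on compound 1 alone, at 21000 nM. The expected step in this assay is a 1.8-fold lower number from compound 1 to compound 3 (0.24 log units; within the scatter), a small one toward a lower number, and it may not clear the usual scatter. Compound 3 is estimated at 12000 nM, with an expected range of 4000 nM to 25000 nM.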

Compound 3, half-maximal effective concentration: > 25000 nM
Compound 3 ended at the assay's limit; the forecaster's own chance of this, stated with the estimate: 25%; at least 2.0-fold (0.31 log units) between middle value and limit.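

In this assay, tert-butyl in place of methoxycarbonyl on an aromatic carbon, meta to a large group, gives an at least 1.1-fold higher number from compound 1 to compound 3 (0.07 log units; that floor lies within the scatter), so at this position a group without the hydrogen-bond acceptors of methoxycarbonyl shows no lower number. For compound 3 the reading > 25000 nM is a limit of the assay and not a number. The size of any rise with this change cannot be read, because the step is bounded by the assay's ceiling: the limit of > 25000 nM in this assay, at which 2 of the 3 values shown sit.

The compounds shown leave open whether any group at this position can bring the number clearly below that of compound 1, which gives 21000 nM. On these data alone, an amine or a longer alkyl chain on the same aromatic carbon would bear on this, and what either would give remains unknown.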